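The source may hold more compounds than are shown below. What is called first, only, known or untested is meant among the compounds shown, and "the series" means these compounds.

Measured compounds:
compound 1 `O=C1CCN[C@@H](c2ccc(O)cc2)CCCN(C(=O)/C=C\c2ccccc2)CCCN1`: > 200000 nM
compound 2 `C[C@@H]1O[C@@H](Oc2ccc([C@H]3CCCN(C(=O)/C=C/c4ccccc4)CCCNC(=O)CCN3)cc2)[C@H](O[C@@H]2O[C@H](COC(=O)c3ccccc3)[C@@H](O)[C@H](O)[C@H]2O)[C@H](O)[C@H]1O`: > 200000 nM

Both measurements come from a functional assay on K562 cells (Homo sapiens) for cytotoxicity, read by MTT assay, with a stated time of 48 h; on this read-out lower numbers stand for stronger inhibition and higher numbers for weaker inhibition. For compound 1 the value > 200000 nM is a limit, not a number. For compound 2 the value > 200000 nM is likewise only a limit. Compound 1 therefore stands at the limit with no number to place it, and the other value shown sits at the same limit, (the limit of > 200000 nM in this assay, at which 2 of the 2 values shown sit).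

Compound 3 `C[C@H]1O[C@@H](Oc2ccc([C@H]3CCCN(C(=O)/C=C\c4ccccc4)CCCNC(=O)CCN3)cc2)[C@@H](O)[C@@H](O)[C@@H]1O` has not yet been measured. It differs from compound 1 by a group of 10 heavy atoms (6 carbon, 4 oxygen; one six-membered non-aromatic ring with 1 hetero atom) in place of a hydrogen atom, on an oxygen on an aromatic ring. For the measured compounds named here, no step between measured compounds is available, so the size of this change can only be judged from what the two values show. Because both values shown sit at the limit of > 200000 nM in this assay, at which 2 of the 2 values shown sit, no movement beyond the scatter is expected in this assay from this change, and the expectation is that compound 3 also returns a limit rather than a number. Compound 3 is estimated at 300000 nM, within 150000 nM to 1000000 nM. This estimate means an expected step that the limit leaves unreadable from compound 1 to compound 3, lying within the scatter.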

Compound 3, half-maximal inhibitory concentration: > 200000 nM
Compound 3 ended at the assay's limit (the forecaster's own chance of this, stated with the estimate: 85%); the middle value does not contradict the limit.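

No step can be read from compound 1 to compound 3 in this assay, since both values are limits and not numbers: the limit of > 200000 nM in this assay, at which 3 of the 3 values shown sit.

The compounds shown leave open whether a group of 10 heavy atoms in place of a hydrogen atom, on an oxygen on an aromatic ring, alters the read-out in this assay at all.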